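Moving a Methyl Group on the Dimethylphenyl Ring

The compounds below may be only part of what the source reports. "The series", "measured", "known", "first", "only" and "open" are said of these compounds alone.

Measured so far:
compound 1, `Cc1nc(-c2cccc(F)c2)c(C(=O)N2CCN(c3cc(Cl)cc(Cl)c3)CC2)o1`: 75.9%
compound 2, `Cc1cc(C)cc(N2CCN(C(=O)c3oc(C)nc3-c3ccccc3)CC2)c1`: 25.6%

Two compounds have been examined in an ADME assay (liver) for metabolic stability, with Liver microsome (Homo sapiens) as the target, read by LC-MS, using microsomes, with a stated time of 1 h, tested at 5 uM; on this read-out higher numbers stand for a more stable compound and lower numbers for a less stable compound. Compound 1 gives 75.9%. Compound 2 gives 25.6%, the lower of the two numbers, and the gap to compound 1 is wide enough to count as a real difference rather than scatter.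

Compound 3, `Cc1ccc(C)c(N2CCN(C(=O)c3oc(C)nc3-c3ccccc3)CC2)c1`, has not yet been measured. It shares every atom with compound 2, joined differently: 2,5-dimethylphenyl in place of 3,5-dimethylphenyl on an amine nitrogen in a ring. Among the measured compounds shown here, no measured pair in this set tracks such a rearrangement, so there is no direct precedent for its effect in this assay.

An estimate for compound 3 is therefore uncertain. The value is expected to lie close to that of compound 2, at about 32%, within a range of 12% to 58%. The implied step of a number 6.4 percentage points higher from compound 2 to compound 3 (within the scatter) is expected to stay within the usual scatter, with no clear direction.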

Compound 3, percent of the compound remaining: 33.8%
Beside the measured number, compound 3's estimate is 1.8 percentage points below it; low and high end bracket the measured number.
By their numbers in this assay, from the lowest: compounds 2 and 3 (each within the scatter of the next); then compound 1.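

In this assay, 2,5-dimethylphenyl in place of 3,5-dimethylphenyl on an amine nitrogen in a ring gives a number 8.2 percentage points higher from compound 2 to compound 3 (within the scatter), so this read-out does not separate the two arrangements of the methyl groups. Among the compounds shown here, this is the first comparison in the set in which only one place changes, and it shows that moving one methyl group on this phenyl ring, with the atoms unchanged, has no effect beyond the usual scatter. No supporting measurement speaks to why the result came out this way.

From the compounds shown here alone, whether a methoxy group or a nitrile on this phenyl ring in place of the methyl groups would shift the number remains open. Compound 1 differs from compound 2 in more than one place, so the contribution of each of those changes cannot be told apart.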